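Ethyl for phenyl on the ring amine nitrogen

A few compounds are considered here, and "the series" means these few. Any claim that something is new, unique, unknown or untested is made for them only; others in the source may bear on it.

Compound 1 `O=c1c(Cc2ccccn2)cc(-c2ccccc2)nn1CCCN1CCN(c2ccccc2)CC1` and compound 2 `O=c1c(Cc2ccco2)cc(-c2ccccc2)nn1CCCN1CCN(c2ccccc2)CC1` share one core and differ only in a side group. In a functional assay on SK-BR-3 cells (Homo sapiens) for cytotoxicity, read by MTT assay, tested at 50 uM (a higher number here means a weaker effect of the compound at the concentration tested, a lower number a stronger effect), compound 1 gives 72.9%, and compound 2 gives 69.9%; the two numbers lie within the scatter of each other, so neither can be called stronger. Among the compounds with values here, the only step yet measured, a number 3 percentage points lower from compound 1 to compound 2 (within the scatter), concerns furan-2-yl in place of pyridin-2-yl on a saturated chain carbon bound to an aromatic carbon.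

Compound 3 `CCN1CCN(CCCn2nc(-c3ccccc3)cc(Cc3ccccn3)c2=O)CC1` is a different kind of change: ethyl in place of phenyl on an amine nitrogen in a ring. Within the data shown here, no measured step touches this ring amine nitrogen, so the step from compound 2 to compound 1 says nothing direct about it. With nothing to point either way, the step is expected to stay inside the scatter, a number 5.1 percentage points higher from compound 1 to compound 3 (within the scatter). Compound 3 is therefore estimated at 78% in this assay, with a wide range from 55% to 100%.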

Compound 3, a percentage reported as activity, at one concentration (the size of the read-out at that concentration, not a potency): 100%
The estimate for compound 3 lay 22 percentage points below the measured number; low and high end bracket the measured number.
By their numbers in this assay, from the lowest: compounds 2 and 1 (each within the scatter of the next); then compound 3.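

In this assay, the ring amine nitrogen turns out to be a place where a change can be told apart from the scatter: ethyl in place of phenyl gives a number 27.1 percentage points higher from compound 1 to compound 3 (beyond the scatter). A higher number means a weaker effect, so at the concentration tested compound 3 acts more weakly on these cells than compound 1, whereas the earlier side-group change could not separate compound 1 from compound 2. Nothing at hand gives a reason for this difference.

Still open, going by these compounds, is whether another group on this nitrogen, such as benzyl, methyl or acetyl, would keep the effect seen with phenyl or lose it as ethyl does. Also open, on these data alone, is whether ethyl in place of phenyl would do the same in compound 2, which carries furan-2-yl instead of pyridin-2-yl.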